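Sulfonyl aryl change in a three-compound series

The source may report more compounds than this note shows. Statements on the series, on what has been measured and on what is new or still open speak of the compounds shown alone.

Of the compounds shown here, three have been measured in a functional assay on HeLa cells for antagonist activity at 5-hydroxytryptamine receptor 6 (Homo sapiens), read by cAMP accumulation and immunoassay; a higher number here means a larger maximal response, a lower number a smaller maximal response. Compound 1 `O=S(=O)(c1ccccc1F)c1cn(C2CCNC2)c2ncccc12` gives 100%. Compound 2 `CN1CCC(n2cc(S(=O)(=O)c3ccccc3F)c3cccnc32)C1` gives 69%; the step of a number 31 percentage points lower from compound 1 to compound 2 (beyond the scatter) is methyl in place of hydrogen on an amine nitrogen in a ring. Compound 3 `CN1CCC(n2cc(S(=O)(=O)c3ccc(F)cc3)c3cccnc32)C1` gives 85% and stands second highest of the three: compound 1 lies higher by a margin beyond the scatter, compound 2 lower by a margin beyond the scatter. The step of a number 16 percentage points higher from compound 2 to compound 3 (beyond the scatter) is 4-fluorophenyl in place of 2-fluorophenyl on a sulfonyl sulfur.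

Compound 4 `CN1CCC(n2cc(S(=O)(=O)c3ccccc3Cl)c3cccnc32)C1` is not yet measured. It differs from compound 3 as follows: 2-chlorophenyl in place of 4-fluorophenyl on a sulfonyl sulfur. Among the compounds with values here, only the step from compound 2 to compound 3 bears on this change: it runs in the opposite direction as regards the phenyl numbering, and was modest. Within the data shown here, the swap of chlorine for fluorine has no measured pair. A modest downward step a number 13 percentage points lower from compound 3 to compound 4 (beyond the scatter) is therefore expected. Compound 4 is estimated at 72%, with a range from 52% to 92%.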

Compound 4, largest response reached (reported as percent of maximum), in percent of the reference or control that the assay uses: 91%
Estimate against measurement, compound 4: 19 percentage points below; measured number inside the range.
By their numbers in this assay, from the lowest: compound 2; then compounds 3, 4 and 1 (each within the scatter of the next, the first and the last beyond it).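

In this assay, chloro in place of fluoro on an aromatic carbon gives a number 22 percentage points higher from compound 2 to compound 4 (beyond the scatter), so the low response of compound 2 does not extend to every 2-halophenyl group on the sulfonyl sulfur; at this position the identity of the halogen matters as well as its place on the phenyl ring. The exchange of 4-fluorophenyl for 2-chlorophenyl gives a number 6 percentage points higher from compound 3 to compound 4 (within the scatter), so the series offers no separation between these two groups. Nothing available explains the difference between the 2-fluorophenyl and 2-chlorophenyl groups.

The shown compounds leave open how 4-chlorophenyl or unsubstituted phenyl on the sulfonyl sulfur would compare, which would help separate the choice of halogen from its place on the ring. Also open, from the compounds shown here alone, is whether the chloro gain persists with hydrogen in place of methyl on the ring amine nitrogen.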